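The compounds below may be only part of what the source reports. "The series", "measured", "known", "first", "only" and "open" are said of these compounds alone.

The three measured compounds, each tested in a functional assay on NCI/ADR-RES cells (Homo sapiens) for inhibition, read by sulforhodamine B assay, with a stated time of 48 h, tested at 10 uM; on this read-out higher numbers stand for more inhibition at the one concentration tested (going by the name of the read-out) and lower numbers for less inhibition:
compound 1 `O=Cc1ccc(-c2cn3ccnc3c(-c3ccc4ncn(C5CCCCC5)c4c3)n2)cc1` gives 37.4%
compound 2 `c1ccc2c(-c3cn4ccnc4c(-c4ccc5ncn(C6CCCCC6)c5c4)n3)cccc2c1` gives 4.43%
compound 3 `CC(=O)c1ccc(-c2cn3ccnc3c(-c3ccc4ncn(C5CCCCC5)c4c3)n2)cc1` gives 4.17%

Compound 3 stands at the lowest of the three numbers, yet compound 2 lies within the scatter of it, so no order between these two can be read; only compound 1 is set apart, by a number 33.2 percentage points lower from compound 1 to compound 3 (beyond the scatter) and a number 33 percentage points lower from compound 1 to compound 2 (beyond the scatter). The unmeasured compound 4 `Clc1ccc(-c2cn3ccnc3c(-c3ccc4ncn(C5CCCCC5)c4c3)n2)cc1` differs from compound 3 in one place: chloro in place of acetyl on an aromatic carbon. For the measured compounds named here, no measured step exchanges an acetyl for a chloro, so none bears directly on this change. The nearest information is the step of a number 0.3 percentage points lower from compound 2 to compound 3 (within the scatter), which shows that swapping one group on the shared core for another left the number where it was, while the formyl-bearing compound 1 alone lies high. Compound 4 is therefore expected to stay low, with the step of a number 5.8 percentage points higher from compound 3 to compound 4 (within the scatter) estimated as small and of uncertain direction. The estimate for compound 4 is 10%, with a range from 0% to 40%. The range is kept wide because a number 33.2 percentage points lower from compound 1 to compound 3 (beyond the scatter) shows that a change at this ring can move the number far.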

Compound 4, a percentage reported as inhibition, at one concentration (the size of the read-out at that concentration, not a potency): 11.1%
The estimate for compound 4 lay 1.1 percentage points below the measured number; the range from low to high includes it.
By their numbers in this assay, from the lowest: compounds 3, 2 and 4 (each within the scatter of the next); then compound 1.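

In this assay, the change of acetyl to chloro on the aromatic carbon gives a number 6.9 percentage points higher from compound 3 to compound 4 (within the scatter) and so does not separate the two groups, although chloro brings one heavy atom in place of three and no carbonyl. The exchange for the ring of compound 2 reads the same way, with a number 6.7 percentage points higher from compound 2 to compound 4 (within the scatter) as the step for 4-chlorophenyl in place of naphthalen-1-yl, while the change from formyl gives a number 26.3 percentage points lower from compound 1 to compound 4 (beyond the scatter) and leaves compound 1 alone apart from compounds 2, 3 and 4. Nothing available explains why only the formyl compound stands apart.

The compounds shown leave open whether the high number depends on formyl itself or would also appear with a hydroxymethyl, a carboxylic acid or an amine at this place. They also leave open whether formyl would give a similar number with a group other than cyclohexyl on the shared core.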